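The source may hold more compounds than are shown below. What is called first, only, known or untested is meant among the compounds shown, and "the series" means these compounds.

In a functional assay on NB-4 cells (Homo sapiens) for cytotoxicity, read by CCK-8 assay, with a stated time of 24 h (on this read-out lower numbers stand for stronger inhibition and higher numbers for weaker inhibition), compound 1 `C=CC(=O)N1C(=O)CC(c2ccc(OC)cc2)Sc2ccccc21` gives 32900 nM. Compound 2 `C=CC(=O)N1C(=O)CCSc2ccccc21` gives 22400 nM and compound 3 `C=CC(=O)N1C(=O)CC(c2cccc(Cl)c2)Sc2ccccc21` gives 31700 nM, so compound 1 stands within the scatter of both. Compound 4 `C=CC(=O)N1C(=O)CC(c2ccc([N+](=O)[O-])cc2)Sc2ccccc21` departs from compound 1 by one change: nitro in place of methoxy on an aromatic carbon. The closest evidence comes from changes at the same substituent: a 1.0-fold lower number from compound 1 to compound 3 (0.02 log units; within the scatter), a 1.5-fold lower number from compound 1 to compound 2 (0.17 log units; within the scatter) and a 1.4-fold higher number from compound 2 to compound 3 (0.15 log units; within the scatter). Within the data shown here, all three stay within the scatter, although none of the measured compounds carries a nitro group. No step beyond the scatter is therefore expected in this assay. The expected step is a 1.2-fold lower number from compound 1 to compound 4 (0.07 log units; within the scatter). The estimated value for compound 4 is 28000 nM, with an expected range from 14000 nM to 50000 nM.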

Compound 4, half-maximal inhibitory concentration: 37700 nM
Compound 4: middle estimate off by 1.3-fold (0.13 log units), on the low side; the range from low to high includes it.
By their numbers in this assay, from the lowest: compounds 2, 3, 1 and 4 (each within the scatter of the next).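

In this assay, a 1.1-fold higher number from compound 1 to compound 4 (0.06 log units; within the scatter), when nitro takes the place of methoxy on an aromatic carbon para to a large group. The earlier steps shown here replaced or removed the whole aromatic group, whereas this one keeps the ring and shows that exchanging only its substituent also stays within the scatter. No measurement available here accounts for this result. The compounds shown leave open whether an amine or a carboxylic acid on this aromatic carbon would go beyond the scatter, and a longer chain there remains equally open.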